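Swapping the anilino ring on a shared triazole-linked core

This account rests on a few compounds, and the source may have more. Where it says the series, first, only, none or still open, it means among the compounds named here.

Measured compounds:
- compound 1, `COc1cc(-c2nc(SCc3cn(CC(=O)NC(=O)Nc4ccccn4)nn3)nc(Nc3ccc(C)cc3)c2C#N)cc(OC)c1OC`: 21000 nM
- compound 2, `COc1cc(-c2nc(SCc3cn(CC(=O)NC(=O)Nc4ccccn4)nn3)nc(Nc3cccc(Cl)c3)c2C#N)cc(OC)c1OC`: 24000 nM
- compound 3, `Cc1ccc(Nc2nc(SCc3cn(CC(=O)NC(=O)Nc4ccccn4)nn3)nc(-c3ccc(C)cc3)c2C#N)cc1`: 39600 nM

All three were tested in a functional assay on MCF7 cells (Homo sapiens) for inhibition, read by MTT assay, with a stated time of 72 h; on this read-out higher numbers stand for weaker inhibition and lower numbers for stronger inhibition. Compound 1 and compound 2 differ only in one place, (3-chlorophenyl in place of 4-methylphenyl on a nitrogen on an aromatic ring), and the step of a 1.1-fold higher number from compound 1 to compound 2 (0.06 log units; within the scatter). Compound 1 and compound 3 differ in their cores, (4-methylphenyl in place of 3,4,5-trimethoxyphenyl on an aromatic carbon), and the step of a 1.9-fold higher number from compound 1 to compound 3 (0.28 log units; within the scatter). Compound 3 gives the highest number of the three, but its gaps to compound 2 and to compound 1 are both within the scatter, so no order among the three can be read from these numbers.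

Compound 4, `Cc1ccc(-c2nc(SCc3cn(CC(=O)NC(=O)Nc4ccccn4)nn3)nc(Nc3cccc(Cl)c3)c2C#N)cc1`, is not yet measured in this assay. Within the data shown here, it differs from compound 3 by 3-chlorophenyl in place of 4-methylphenyl on a nitrogen on an aromatic ring, which is the same change as the one from compound 1 to compound 2, made on the core of compound 3 instead of the core of compound 1. The earlier step, a 1.1-fold higher number from compound 1 to compound 2 (0.06 log units; within the scatter), barely moved the number. Among the measured compounds shown here, a step of about the same size is expected from compound 3 to compound 4, a 1.1-fold higher number from compound 3 to compound 4 (0.05 log units; within the scatter), because the only measured example of this change, a 1.1-fold higher number from compound 1 to compound 2 (0.06 log units; within the scatter), lies within the scatter. Compound 4 is therefore estimated at 44000 nM in this assay, with a plausible range from 22000 nM to 88000 nM.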

Compound 4, half-maximal inhibitory concentration: 14900 nM
Beside the measured number, compound 4's estimate is 3.0-fold (0.47 log units) above it; measured number below the stated range.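

In this assay, putting 3-chlorophenyl in place of 4-methylphenyl on the core of compound 3 gives a modest step, a 2.7-fold lower number from compound 3 to compound 4 (0.42 log units; beyond the scatter), and this does not match what the same change did on the core of compound 1: the same change on two cores in this assay, a 1.1-fold higher number (0.06 log units; within the scatter) from compound 1 to compound 2 and a 2.7-fold lower number (0.42 log units; beyond the scatter) from compound 3 to compound 4, 3.0-fold (0.48 log units) apart, beyond the scatter of two such steps. The same four compounds can also be read the other way, through the change from 3,4,5-trimethoxyphenyl to 4-methylphenyl on an aromatic carbon, which gives a 1.6-fold lower number from compound 2 to compound 4 (0.21 log units; within the scatter), a step that taken alone is within the scatter but still differs from its earlier counterpart: the same change on two cores in this assay, a 1.9-fold higher number (0.28 log units; within the scatter) from compound 1 to compound 3 and a 1.6-fold lower number (0.21 log units; within the scatter) from compound 2 to compound 4, 3.0-fold (0.48 log units) apart, beyond the scatter of two such steps. Together these show that, in this small set, the effect of the anilino change did not carry over unchanged from one core to the other, but they do not show why, and they rest on one pair of cores and a single value per compound.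

Going by these compounds, it remains open whether a plain phenyl or a 4-fluorophenyl on that nitrogen would follow the core of compound 1 or the core of compound 3. A carboxylic acid or an amine on the ring at the aromatic carbon could also show whether the mismatch extends beyond these two cores.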